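A Nitro Group Enters on the Longer-Chain Hydroxamate

The source may hold more compounds than are shown below. What is called first, only, known or untested is meant among the compounds shown, and "the series" means these compounds.

Compound 2 `O=C(CCCCCCC(=O)Nc1nc2ccccc2s1)NO` gives the lowest number of the three measured compounds in a functional assay on ASPC1 cells (Homo sapiens) for cytotoxicity (on this read-out lower numbers stand for stronger inhibition and higher numbers for weaker inhibition), at 5.69 ug/mL. For the measured compounds named here, compound 3 `Cc1ccc2nc(NC(=O)CCCCC(=O)NO)sc2c1` gives 13.3 ug/mL in this assay, and compound 1 `COc1ccc2nc(NC(=O)CCCCC(=O)NO)sc2c1` gives 23.9 ug/mL; both of those gaps to compound 2 lie beyond the scatter, the one to compound 1 being the wider. Going by the values given here, the only step between compounds that differ in a single place, a 1.8-fold lower number from compound 1 to compound 3 (0.25 log units; within the scatter), concerns a substituent on an aromatic carbon of the shared core and did not move the number beyond the scatter. Compound 4 `O=C(CCCCCCC(=O)Nc1nc2ccc([N+](=O)[O-])cc2s1)NO` differs from compound 2 by nitro in place of hydrogen on an aromatic carbon. Among the compounds with values here, no measured step concerns the entry of a nitro group, and none concerns a change on the longer chain that compound 2 carries; the step from compound 1 to compound 3 is the nearest guide, and it was small. On that basis the expectation is no step beyond the scatter in this assay. Compound 4 is estimated at 5.5 ug/mL, with a range from 2.5 ug/mL to 12 ug/mL. This estimate corresponds to an expected 1.0-fold lower number from compound 2 to compound 4 (0.01 log units; within the scatter).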

Compound 4, half-maximal inhibitory concentration: 1.65 ug/mL
For compound 4 the middle estimate is 3.3-fold (0.52 log units) above the measured one, and the stated range ends above it.
By their numbers in this assay, from the lowest: compound 4; then compound 2; then compounds 3 and 1 (each within the scatter of the next).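

Entry of nitro on an aromatic carbon of the six-membered ring of carbon only gives, in this assay, a 3.4-fold lower number from compound 2 to compound 4 (0.54 log units; beyond the scatter) and so shows that a change at this carbon can move the number beyond the scatter. The earlier step, a 1.8-fold lower number from compound 1 to compound 3 (0.25 log units; within the scatter) on the shorter chain, exchanged one substituent for another and stayed within the scatter, so it did not show this. Nothing at hand bears on what lies behind the lower number of compound 4.

The compounds shown leave open whether nitro would give a step of similar size on the shorter chain of compound 1 and compound 3, where only methoxy and methyl appear. They also leave open whether an amine or a carboxylic acid on this same aromatic carbon of the longer-chain series would lower the number as nitro does.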